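A few compounds are considered here, and "the series" means these few. Any claim that something is new, unique, unknown or untested is made for them only; others in the source may bear on it.

Measured in a functional assay on HL-60 cells (Homo sapiens) for cytotoxicity, with a stated time of 48 h; a lower number here means that less compound is tolerated, a higher number that more compound is tolerated:
- compound 1, `Cc1c(C(=O)/C=C/c2cccc([N+](=O)[O-])c2)[n+]([O-])c2ccccc2[n+]1[O-]`, 62000 nM
- compound 2, `COc1ccc(/C=C/C(=O)c2c(C)[n+]([O-])c3ccccc3[n+]2[O-])cc1`, 16000 nM

Compound 2 stands at the lowest of the two numbers in this assay; the nearest, compound 1, gives a higher number, beyond the scatter. Among the measured compounds shown here, no pair differing in one place has been measured, so no step size is known.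

Compound 3, `Cc1c(C(=O)/C=C/c2ccc(Cl)c(Cl)c2)[n+]([O-])c2ccccc2[n+]1[O-]`, is the next candidate for this assay. It differs from compound 2 by 3,4-dichlorophenyl in place of 4-methoxyphenyl on a double-bonded chain carbon bound to a double-bonded chain carbon. For the measured compounds named here, nothing measured so far tells how this exchange on the double-bonded chain carbon moves the number; the only comparison available, compound 1 against compound 2, concerns a different substituent. For compound 3 the expected step from compound 2 is a 1.3-fold higher number from compound 2 to compound 3 (0.10 log units; within the scatter), estimated as none beyond the scatter, with the direction left open. Compound 3 is expected to give about 20000 nM in this assay, within a range of 6000 nM to 60000 nM.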

Compound 3, half-maximal cytotoxic concentration: 27000 nM
Beside the measured number, compound 3's estimate is 1.4-fold (0.13 log units) below it; the measured number falls inside the stated range.
By their numbers in this assay, from the lowest: compounds 2 and 3 (each within the scatter of the next); then compound 1.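

Among the compounds shown here, this is the first step between compounds differing in one place: in this assay, 3,4-dichlorophenyl in place of 4-methoxyphenyl on a double-bonded chain carbon bound to a double-bonded chain carbon gives a step within the scatter (a 1.7-fold higher number from compound 2 to compound 3 (0.23 log units; within the scatter)). The exchange keeps 8 heavy atoms and the six-membered aromatic ring of carbon only, while replacing the oxygen-bearing group, with its 1 hydrogen-bond acceptor, by a group with two chlorines and 0 acceptors, and this does not separate compound 2 from compound 3 in this read-out. No measurement shown accounts for this step.

On these data alone, whether an unsubstituted phenyl, or a ring carrying an amine or a carboxylic acid, would also stay within the scatter of compound 2 remains open. A single step also leaves open whether a longer chain at this place would move the number.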